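A few compounds are considered here, and "the series" means these few. Any claim that something is new, unique, unknown or untested is made for them only; others in the source may bear on it.

Measured compounds:
- compound 1 `CC(O)(C(=O)Nc1ccc(S(=O)(=O)c2ccccc2O)cc1)C(F)(F)F`, in a functional assay (Cavia porcellus) with sulfonylurea receptors; K-ATP channels (Homo sapiens) as the target (a lower number here means a stronger inhibitor, a higher number a weaker inhibitor), compound 1 gives 3090 nM
- compound 2 `Cc1ccccc1S(=O)(=O)c1ccc(NC(=O)C(C)(O)C(F)(F)F)cc1`, in this assay compound 2 gives 5100 nM
- compound 3 `CC(O)(C(=O)Nc1ccc(S(=O)(=O)c2ccc([N+](=O)[O-])cc2)cc1)C(F)(F)F`, in this assay compound 3 gives > 30000 nM, which is a limit of the assay and not a number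

Compound 3 thus stands at the weak end of the three: the step of an at least 9.7-fold higher number from compound 1 to compound 3 (0.98 log units; beyond the scatter) and the step of an at least 5.8-fold higher number from compound 2 to compound 3 (0.76 log units; beyond the scatter) both run beyond the scatter, while the step of a 1.7-fold higher number from compound 1 to compound 2 (0.22 log units; within the scatter) stays within it. Evidence on compound 3 is confined to the limit of > 30000 nM in this assay, at which 1 of the 3 values shown sits.

Compound 4 `CC(O)(C(=O)Nc1ccc(S(=O)(=O)c2cccnc2)cc1)C(F)(F)F` differs from compound 3 in one place: pyridin-3-yl in place of 4-nitrophenyl on a sulfonyl sulfur. The measured steps that bear on this change are those from compound 1 and compound 2 to compound 3, where exchanging a small aryl group for the 4-nitrophenyl on the sulfonyl sulfur moved the number beyond the scatter. Going by the values given here, removing the 4-nitrophenyl again is therefore expected to move the number back down in this assay, roughly toward the range of compound 1 and compound 2, though the heteroaryl ring has no direct precedent here.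

Compound 4 is estimated at 8000 nM, between 2500 nM and 30000 nM, an expected step of an at least 3.7-fold lower number from compound 3 to compound 4 (0.57 log units; beyond the scatter).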

Compound 4, half-maximal inhibitory concentration: 3500 nM
Estimate against measurement, compound 4: 2.3-fold (0.36 log units) above; the measured number falls inside the stated range.
By their numbers in this assay, from the lowest: compounds 1, 4 and 2 (each within the scatter of the next). At a limit, above all of these: compound 3.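

In this assay, a pyridin-3-yl on the sulfonyl sulfur, the first ring here with a hetero atom, reads the same as the two substituted phenyl rings: a 1.1-fold higher number from compound 1 to compound 4 (0.05 log units; within the scatter), and a 1.5-fold lower number from compound 2 to compound 4 (0.16 log units; within the scatter). Compound 3 with its 4-nitrophenyl therefore stands apart from three compounds rather than two, with an at least 8.5-fold lower number from compound 3 to compound 4 (0.93 log units; beyond the scatter), so at this place the earlier loss is not a general feature of exchanging the aryl group and is so far confined to compound 3. That step gives only a lower bound on the size of the change, as it rests on a limit of the assay and not a number for compound 3: the limit of > 30000 nM in this assay, at which 1 of the 4 values shown sits.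

The compounds shown leave open whether the nitro group itself sets compound 3 apart, a question that a plain phenyl or a 4-aminophenyl on the sulfonyl sulfur would bear on. They also leave open whether the ring nitrogen matters to the reading of compound 4, for which a pyridin-4-yl or a pyridin-2-yl at the same place would be the nearest comparison.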